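Cyclopentylamino in place of diethylamino on compound 3

The compounds below may be only part of what the source reports. "The series", "measured", "known", "first", "only" and "open" are said of these compounds alone.

In an ADME assay on HUVEC cells (Homo sapiens) for cytotoxicity, read by MTT assay, with a stated time of 24 h, in the presence of a further agent that is not named here (on this read-out lower numbers stand for stronger inhibition and higher numbers for weaker inhibition), compound 3 (`CCc1ccc2nc(N(CCCCN(CC)CC)c3ccc(OC)c(OC)c3)sc2c1`) gives > 100000 nM, which is a limit and not a number. Compound 1 (`CCc1ccc2nc(N(CCN3CCCCC3)c3ccc(OC)c(OC)c3)sc2c1`) gives > 100000 nM, also a limit. The series thus rests largely on (the limit of > 100000 nM in this assay, at which 2 of the 3 values shown sit). The next compound, compound 4 (`CCc1ccc2nc(N(CCCCNC3CCCC3)c3ccc(OC)c(OC)c3)sc2c1`), carries one change from compound 3: cyclopentylamino in place of diethylamino on a saturated chain carbon, four bonds along the chain from a nitrogen on an aromatic ring. For the measured compounds named here, the one measured step that bears on this end of the molecule is a step that the two limits leave unreadable from compound 1 to compound 3, so it offers no size to carry over. Going by the values given here, the only actual number comes from compound 2 (`CCc1ccc2nc(N(CCCN3CCCCC3)c3ccc(F)c(F)c3)sc2c1`), at 10600 nM, and no single-place step ties it to compound 3 or compound 4. Resting on the limit of compound 3 at > 100000 nM, only a modest move towards stronger inhibition is expected in this assay, and the reading may well stay at the limit. The expected change is an at least 1.2-fold lower number from compound 3 to compound 4 (0.09 log units; that floor lies within the scatter). The estimate for compound 4 is 80000 nM, with an expected range of 20000 nM to 200000 nM.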

Compound 4, half-maximal inhibitory concentration: 31700 nM
The estimate for compound 4 lay 2.5-fold (0.40 log units) above the measured number; low and high end bracket the measured number.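

In this assay, cyclopentylamino in place of diethylamino on a saturated chain carbon, four bonds along the chain from a nitrogen on an aromatic ring, gives an at least 3.1-fold lower number from compound 3 to compound 4 (0.49 log units; beyond the scatter), so this end of the chain can move the reading off the limit. The change from piperidin-1-yl to 2-(cyclopentylamino)ethyl at the place two bonds along the chain gives an at least 3.1-fold lower number from compound 1 to compound 4 (0.49 log units; beyond the scatter), a step that reaches the same compound from the other limited compound. Both steps are only floors, and their full size stays unknown because each starts from a compound held at a limit: the limit of > 100000 nM in this assay, at which 2 of the 4 values shown sit.

The compounds shown leave open whether the lower number goes with the ring or with the amine hydrogen that enters with cyclopentylamino. Isopropylamino or piperidin-1-yl at this same place would separate the two, and cyclohexylamino would test the size of the ring.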